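A few compounds are considered here, and "the series" means these few. Any claim that something is new, unique, unknown or untested is made for them only; others in the source may bear on it.

Compound 1 `Cn1c(-c2ccc([N+](=O)[O-])cc2)nc2cc(C(F)(F)F)ccc21`: > 100000 nM
Compound 2 `Cn1c(-c2ccc(NC(=O)CN3CCCC3)cc2)nc2cc(C(F)(F)F)ccc21`: > 100000 nM
Compound 3 `CC(=O)Nc1ccc(-c2nc3cc(C(F)(F)F)ccc3n2C)cc1`: > 100000 nM

In an ADME assay on Vero cells (Chlorocebus sabaeus) for cytotoxicity (on this read-out higher numbers stand for lower toxicity in this test and lower numbers for higher toxicity in this test), compound 1 gives > 100000 nM, which is a limit of the assay rather than a number. Compound 2 also gives only a limit. Compound 3 likewise stands at a limit. The steps a step that the two limits leave unreadable from compound 1 to compound 2, a step that the two limits leave unreadable from compound 1 to compound 3 and a step that the two limits leave unreadable from compound 2 to compound 3 therefore cannot be read, as all three values sit at the limit of > 100000 nM in this assay, at which 3 of the 3 values shown sit. Compound 4 `O=[N+]([O-])c1ccc(-c2nc3cc(C(F)(F)F)ccc3[nH]2)cc1` differs from compound 1 by hydrogen in place of methyl on an aromatic nitrogen. Going by the values given here, none of the measured steps involves this kind of change, and all of them are unreadable, so no direction can be drawn from them. Compound 4 is expected to stay at the same limit, with an estimated step of a number no higher from compound 1 to compound 4 (the limit leaves the size open). For compound 4 the estimated value in this assay is 100000 nM, between 50000 nM and 200000 nM.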

Compound 4, half-maximal cytotoxic concentration: 45000 nM
Estimate against measurement, compound 4: 2.2-fold (0.35 log units) above, outside the stated range (below it).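

In this assay, hydrogen in place of methyl on the aromatic nitrogen gives an at least 2.2-fold lower number from compound 1 to compound 4 (0.34 log units; beyond the scatter), so a lower number here means higher toxicity in this test. The steps among compound 1, compound 2 and compound 3 cannot be read, which makes this aromatic nitrogen the first place where a change shows a direction. Compound 4 is the only compound shown with a number rather than a limit: the limit of > 100000 nM in this assay, at which 3 of the 4 values shown sit.

As far as these compounds go, the full size of this step stays open, since the value of compound 1 is a limit. Also open, from the compounds shown here alone, is how an ethyl group or a longer chain on this nitrogen would compare with methyl and hydrogen.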